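This account rests on a few compounds, and the source may have more. Where it says the series, first, only, none or still open, it means among the compounds named here.

Compound 1 `Cn1c(-c2ccc(NC(=O)CSc3nc4ccccc4o3)cc2)nc(-c2ccccc2)c1-c1ccccc1` and compound 2 `Cc1nnc(SCC(=O)Nc2ccc(-c3nc(-c4ccccc4)c(-c4ccccc4)n3C)cc2)s1` share one core and differ only in the group carried on the sulfur. In a functional assay on HT-29 cells (Homo sapiens) for cytotoxicity, read by MTT assay, with a stated time of 24 h (on this read-out lower numbers stand for stronger inhibition and higher numbers for weaker inhibition), compound 1 gives 11 ug/mL, and compound 2 gives 2.7 ug/mL. Compound 2 thus holds the lowest of the two numbers, its nearest neighbour being compound 1, separated by a 4.1-fold lower number from compound 1 to compound 2 (0.61 log units; beyond the scatter). Compound 3 `Cn1c(-c2ccc(NC(=O)CN3CCN(c4ccccc4)CC3)cc2)nc(-c2ccccc2)c1-c1ccccc1` is not yet measured. The change is 4-phenylpiperazin-1-yl in place of (5-methyl-1,3,4-thiadiazol-2-yl)sulfanyl on a saturated chain carbon bound to a carbonyl carbon. Within the data shown here, only the step of a 4.1-fold lower number from compound 1 to compound 2 (0.61 log units; beyond the scatter) bears on this change, and only loosely: there one heteroaryl group on the sulfur was exchanged for another, whereas here the whole sulfanyl-linked group leaves and an amine-linked group enters. That step shows the number can move beyond the scatter when this part is altered, but its direction offers no guide to the present change. Compound 3 is expected to show a modest rise, a 2.2-fold higher number from compound 2 to compound 3 (0.35 log units; beyond the scatter). The estimate for compound 3 is 6 ug/mL, with a range from 2 ug/mL to 18 ug/mL.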

Compound 3, half-maximal inhibitory concentration: 8.6 ug/mL
For compound 3 the middle estimate is 1.4-fold (0.16 log units) below the measured one; the range from low to high includes it.
By their numbers in this assay, from the lowest: compound 2; then compounds 3 and 1 (each within the scatter of the next).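

Until now only sulfanyl-linked heteroaryl groups had stood on the saturated chain carbon bound to a carbonyl carbon. In this assay the sulfur-free 4-phenylpiperazin-1-yl group gives a 3.2-fold higher number from compound 2 to compound 3 (0.50 log units; beyond the scatter) and so does not keep the level of the (5-methyl-1,3,4-thiadiazol-2-yl)sulfanyl group, while against the (1,3-benzoxazol-2-yl)sulfanyl group it gives a 1.3-fold lower number from compound 1 to compound 3 (0.11 log units; within the scatter), which leaves compound 2 as the only one of the three set apart beyond the scatter. Nothing at hand explains these differences.

The compounds shown leave open whether the phenyl on the piperazine matters, which a 4-methylpiperazin-1-yl group would test, and whether the piperazine ring itself matters, which a morpholine would test. Also open, from the compounds shown here alone, is whether the level of compound 2 depends on the methyl on its thiadiazole, which the unsubstituted 1,3,4-thiadiazol-2-yl group would address.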